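A few compounds are considered here, and "the series" means these few. Any claim that something is new, unique, unknown or untested is made for them only; others in the source may bear on it.

Of the compounds shown here, three of one shared core have been tested in a functional assay on the whole organism (strain Wistar albino) for inhibition, with Rattus norvegicus as the target, read by paw edema, with a stated time of 1 h, at a dose of 40 mg/kg by the oral route; a higher number here means more inhibition at the dose given (going by the name of the read-out), a lower number less inhibition. Compound 1 `COc1ccc(N2C(=O)CSC2c2sc(-c3ccccc3)nc2C)cc1` gives 52.3%, compound 2 `COc1ccc(N2C(=O)CSC2c2sc(Cc3ccc(Cl)cc3)nc2C)cc1` gives 20.9%, and compound 3 `Cc1nc(-c2ccc(Cl)cc2)sc1C1SCC(=O)N1c1ccc(F)cc1` gives 63.4%. Compound 2 therefore stands lowest of the three. Among the compounds with values here, the one measured step that differs in one place, a number 31.4 percentage points lower from compound 1 to compound 2 (beyond the scatter), concerns 4-chlorobenzyl in place of phenyl on an aromatic carbon, a change at a different place from the one now considered. Compound 4 `Cc1nc(Cc2ccc(Cl)cc2)sc1C1SCC(=O)N1c1ccc(Cl)cc1` differs from compound 2 by chloro in place of methoxy on an aromatic carbon. Within the data shown here, no measured step covers this exact exchange, so it is expected to produce no step beyond the scatter in this assay, and the expected change is a number 7.1 percentage points higher from compound 2 to compound 4 (within the scatter). Compound 4 is thus estimated at 28%, between 10% and 50%.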

Compound 4, a percentage reported as inhibition, in the whole organism at one dose (the size of the read-out at that dose, not a potency): 48.9%
Estimate against measurement, compound 4: 20.9 percentage points below; the measured number falls inside the stated range.
By their numbers in this assay, from the lowest: compound 2; then compounds 4 and 1 (each within the scatter of the next); then compound 3.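

In this assay, chloro in place of methoxy on the six-membered aromatic ring gives a number 28 percentage points higher from compound 2 to compound 4 (beyond the scatter) and so shows that this position, too, can change the result. The earlier step concerned a different place and could not show this. Nothing measured here explains the gain.

From the compounds shown here alone, whether an amine, a hydroxyl or a carboxylic acid at this position would give more or less inhibition stays open. So does whether the same exchange made on compound 1 would give a step of similar size.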